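The compounds below may be only part of what the source reports. "The series", "measured", "known", "first", "only" and "open" are said of these compounds alone.

Measured so far in a functional assay on B16-F10 cells (Mus musculus) for antiproliferative activity, read by MTT assay, with a stated time of 48 h; a lower number here means a stronger inhibitor, a higher number a weaker inhibitor:
compound 1 `CCCCOc1ccc(C(=O)/C=C/c2c(/C=C/c3ccc(OC)cc3)cc(OC)cc2OC)cc1` gives 5.3 ug/mL
compound 2 `COc1ccc(/C=C/c2cc(OC)cc(OC)c2/C=C/C(=O)c2ccc(Br)cc2)cc1` gives 6.5 ug/mL
compound 3 `COc1ccc(/C=C/c2cc(OC)cc(OC)c2/C=C/C(=O)c2ccc(C)cc2)cc1` gives 5.3 ug/mL

Compound 3 stands level with compound 1 at the digits printed, the two together the lowest of the three numbers; the remaining gap in the set is a 1.2-fold lower number from compound 2 to compound 3 (0.09 log units; within the scatter), within the scatter. The whole set spans only a 1.2-fold higher number from compound 1 to compound 2 (0.09 log units; within the scatter) and no change at the digits printed from compound 1 to compound 3 (within the scatter), so replacing the substituent on this aromatic carbon has so far moved nothing beyond the scatter.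

Compound 4 `COc1ccc(/C=C/c2cc(OC)cc(OC)c2/C=C/C(=O)c2ccc(-c3ccccc3)cc2)cc1` is the next analogue: phenyl in place of methyl on an aromatic carbon. For the measured compounds named here, no measured step covers a phenyl at this position, so the flat steps from compound 1 to compound 2 and from compound 1 to compound 3 are the only guide. Compound 4 is therefore expected to sit close to compound 3, with an estimated step of a 1.0-fold higher number from compound 3 to compound 4 (0.02 log units; within the scatter), a change not expected to exceed the scatter. The estimate for compound 4 is 5.5 ug/mL, with a range from 2.5 ug/mL to 12 ug/mL.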

Compound 4, half-maximal inhibitory concentration: 10.6 ug/mL
Estimate against measurement, compound 4: 1.9-fold (0.28 log units) below, within the range that was stated.
By their numbers in this assay, from the lowest: compounds 1, 3, 2 and 4 (each within the scatter of the next).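

In this assay, for the compounds shown here, phenyl, the first group here to bring a ring of its own to this aromatic carbon, still stays within the scatter of the other three: a 2.0-fold higher number from compound 3 to compound 4 (0.30 log units; within the scatter), a 1.6-fold higher number from compound 2 to compound 4 (0.21 log units; within the scatter) and a 2.0-fold higher number from compound 1 to compound 4 (0.30 log units; within the scatter). Across compounds 1 to 4, the four groups at this position therefore remain indistinguishable, although the steps from methyl and butoxy to phenyl are the widest in the set. No supporting data bear on these steps. As far as these compounds go, it remains open whether an amine or a carboxylic acid at this position would move the number beyond the scatter.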